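The source may hold more compounds than are shown below. What is called first, only, known or untested is meant among the compounds shown, and "the series" means these compounds.

Measured so far:
compound 1, `COc1cc(-c2cc(/C=C/C(=O)c3ccc(N)cc3)[nH]n2)cc(OC)c1OC` — 13400 nM
compound 2, `COc1ccc(-c2cc(/C=C/C(=O)c3ccc(OC)c(OC)c3)[nH]n2)cc1` — 8730 nM

Both values come from a functional assay on SN12C cells (Homo sapiens) for inhibition, read by sulforhodamine B assay, with a stated time of 48 h; on this read-out higher numbers stand for lower toxicity in this test and lower numbers for higher toxicity in this test. On this read-out compound 1 gives 13400 nM, the highest of the two numbers; compound 2 gives 8730 nM, and the gap between the two lies within the scatter, so the two compounds cannot be told apart here. Within the data shown here, compound 2 differs from compound 1 in more than one place, so no single step can be drawn between them.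

The unmeasured compound 3, `COc1cc(-c2cc(/C=C/C(=O)c3ccc(Cl)c(Cl)c3)[nH]n2)cc(OC)c1OC`, is reached from compound 1 by one change: 3,4-dichlorophenyl in place of 4-aminophenyl on a carbonyl carbon. Among the measured compounds shown here, no measured pair shows this change, so its effect is unknown from the present numbers. The expectation for the step from compound 1 to compound 3 in this assay is a small one, if any, with a lower number slightly more likely than a higher one: a 1.5-fold lower number from compound 1 to compound 3 (0.17 log units; within the scatter). Compound 3 is therefore estimated at 9000 nM, with a range from 3000 nM to 30000 nM.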

Compound 3, concentration lethal to 50% of the cells: > 100000 nM
Compound 3 gave a limit, no number (the forecaster's own chance of this, stated with the estimate: 10%); middle value at least 11-fold (1.04 log units) away from the limit.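

In this assay, 3,4-dichlorophenyl in place of 4-aminophenyl on a carbonyl carbon gives an at least 7.4-fold higher number from compound 1 to compound 3 (0.87 log units; beyond the scatter), so this position can move the read-out beyond the scatter, which compounds 1 and 2 could not show. Compound 3 gives > 100000 nM, which is a limit of the assay and not a number. The step is therefore a bound and not a size, and it rests on a single value at that limit: the limit of > 100000 nM in this assay, at which 1 of the 3 values shown sits.

The step removes the amine and adds both chlorines at once, so the compounds shown do not separate the loss of the one from the arrival of the other. A plain phenyl or a 4-chlorophenyl on the same carbonyl carbon would bear on that question, and a 4-hydroxyphenyl there would test whether the read-out stays near that of compound 1.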